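The compounds below may be only part of what the source reports. "The series", "measured", "known", "first", "only" and "open" are said of these compounds alone.

Measured compounds:
- Compound 1 `CCCCCCCC/C=C/CCCCCCCC(=O)Nc1ccccc1OC`: 8000 nM
- Compound 2 `CCCCCCCC/C=C/CCCCCCCC(=O)Nc1ccc(OC)cc1OC`: 3000 nM
- Compound 3 `CCCCCCCC/C=C/CCCCCCCC(=O)Nc1cc(C(=O)OC)ccc1OC`: 430 nM

In an assay on microsomes from intestine for inhibition of acyl-CoA:cholesterol acyltransferase (Oryctolagus cuniculus) (on this read-out higher numbers stand for weaker inhibition and lower numbers for stronger inhibition), compound 3 gives the lowest of the three numbers; compound 2 stands a 2.7-fold lower number from compound 1 to compound 2 (0.43 log units; beyond the scatter) from compound 1, while the larger step of a 19-fold lower number from compound 1 to compound 3 (1.27 log units; beyond the scatter) separates compound 1 from compound 3, and the values of compound 2 and compound 3 lie well apart.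

Compound 4 `CCCCCCCC/C=C/CCCCCCCC(=O)Nc1cc(C(=O)OC)c(OC)cc1OC` has not been measured. Its difference from compound 3 is methoxy in place of hydrogen on an aromatic carbon. Within the data shown here, the only measured step of the same kind is the one from compound 1 to compound 2, a methoxy entering on an aromatic carbon para to the large group, which gave a 2.7-fold lower number from compound 1 to compound 2 (0.43 log units; beyond the scatter). Nothing shows whether this gain carries over onto compound 3, where the methoxycarbonyl group already stands; the data give no second instance of the change.

On that single precedent, compound 4 is expected to show a modest lowering, a 2.0-fold lower number from compound 3 to compound 4 (0.29 log units; within the scatter), in this assay, somewhat below the step seen from compound 1 to compound 2 to allow for the uncertainty of carrying it across. The estimated value for compound 4 is 220 nM, with a range from 80 nM to 600 nM.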

Compound 4, half-maximal inhibitory concentration: 1100 nM
For compound 4 the middle estimate is 5.0-fold (0.70 log units) below the measured one, and the stated range ends below it.
By their numbers in this assay, from the lowest: compound 3; then compound 4; then compound 2; then compound 1.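

In this assay, methoxy in place of hydrogen on the aromatic carbon ortho to a methoxycarbonyl group, meta to a methoxy group and para to a large group no longer lowers the number, and instead gives a 2.6-fold higher number from compound 3 to compound 4 (0.41 log units; beyond the scatter). The same change therefore runs in opposite directions on the two cores, so its effect depends on what the core already carries: the same change on two cores in this assay, a 2.7-fold lower number (0.43 log units; beyond the scatter) from compound 1 to compound 2 and a 2.6-fold higher number (0.41 log units; beyond the scatter) from compound 3 to compound 4, 6.8-fold (0.83 log units) apart, beyond the scatter of two such steps. The methoxycarbonyl group still lowers the number when the added methoxy is present, with a 2.7-fold lower number from compound 2 to compound 4 (0.44 log units; beyond the scatter), but that gain is much smaller than on the core without it: the same change on two cores in this assay, a 19-fold lower number (1.27 log units; beyond the scatter) from compound 1 to compound 3 and a 2.7-fold lower number (0.44 log units; beyond the scatter) from compound 2 to compound 4, 6.8-fold (0.83 log units) apart, beyond the scatter of two such steps. The two changes therefore do not simply add up in this series, and compound 3, without the added methoxy, keeps the lowest number of the four.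

The compounds shown leave open whether the reversal belongs to methoxy itself or to any group at this position, a question that a methyl or a chlorine there could settle. They also leave open whether the gain depends on the ester, which a carboxylic acid or a primary amide in place of the methoxycarbonyl group would test.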